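The compounds below may be only part of what the source reports. "The series", "measured", "known", "first", "only" and "open" are said of these compounds alone.

Compound 3 `Cc1c(C#Cc2ccc(CCC(=O)O)cc2)ccnc1Cl` gives in an in vitro functional assay on 1321-N1 cells for agonist activity at Free fatty acid receptor 1 (Homo sapiens), read by fluorescence, spectrophotometry and calcium flux (a lower number here means a smaller maximal response, a higher number a larger maximal response), a maximal response of 101%, the highest of the three numbers measured in this series, though compound 2 `O=C(O)CCc1ccc(C#Cc2ccnc(-c3ccccc3)c2)cc1` with 97% and compound 1 `Cc1ccccc1-c1cc(C#Cc2ccc(CCC(=O)O)cc2)ccn1` with 92% both sit within the scatter of it, so no order among the three can be read from these numbers. Compound 4 `O=C(O)CCc1ccc(C#Cc2ccnc(Cl)c2)cc1` has not yet been measured. The change from compound 3 to compound 4 is hydrogen in place of methyl on an aromatic carbon. Within the data shown here, one measured step bears directly on it: the same exchange between compound 1 and compound 2 gave a number 5 percentage points higher from compound 1 to compound 2 (within the scatter), a movement that stays within the scatter. Among the measured compounds shown here, with only that step as a guide, and with all three measured numbers close to the full response of the reference, no movement beyond the scatter is expected, and the expected step of a number 2 percentage points lower from compound 3 to compound 4 (within the scatter) is taken as essentially flat. The expected value for compound 4 in this assay is therefore 99%, with a range from 88% to 108%.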

Compound 4, largest response reached (reported as efficacy), in percent of the reference or control that the assay uses: 94%
Estimate against measurement, compound 4: 5 percentage points above; measured number inside the range.
By their numbers in this assay, from the lowest: compounds 1, 4, 2 and 3 (each within the scatter of the next).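

In this assay, hydrogen in place of methyl on this aromatic carbon, ortho to a chloro group and two atoms from the ring nitrogen, gives a number 7 percentage points lower from compound 3 to compound 4 (within the scatter) and so leaves the maximal response unresolved from the methyl compound. At the other substituted carbon, chloro and the larger aromatic groups also cannot be told apart, with a number 3 percentage points lower from compound 2 to compound 4 (within the scatter) for chloro in place of phenyl and a number 2 percentage points higher from compound 1 to compound 4 (within the scatter) for chloro in place of 2-methylphenyl. The exchange of methyl for hydrogen now stands on two cores, and the two steps cannot be separated: the same change on two cores in this assay, a number 5 percentage points higher (within the scatter) from compound 1 to compound 2 and a number 7 percentage points lower (within the scatter) from compound 3 to compound 4, 12 percentage points apart, within the scatter of two such steps.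

All four numbers lie within the scatter of one another, so the compounds shown identify no group that moves the maximal response. As far as these compounds go, whether an amine or a longer chain in place of the methyl would move it stays open.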